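A few compounds are considered here, and "the series" means these few. Any claim that something is new, unique, unknown or untested is made for them only; others in the source may bear on it.

Of the compounds shown here, two of one shared core have been measured in a physicochemical assay for lipophilicity, using the shake flask method, measured as octanol-water partition; on this read-out lower numbers stand for lower lipophilicity and higher numbers for higher lipophilicity. Compound 1, `COc1ccc(Cl)cc1-n1ncc(-c2nnc(-c3ccc(Br)cc3)o2)c1C`, gives 4.88. Compound 2, `COc1ccc(Cl)cc1-n1ncc(-c2nnc(-c3ccc(Cl)cc3)o2)c1C`, gives 4.51. Among the compounds with values here, the one measured step between them is a number 0.37 log units lower from compound 1 to compound 2 (beyond the scatter), and this is the only comparison available. Compound 2 therefore holds the lowest of the two numbers, with compound 1 standing a modest step higher and beyond the scatter.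

The next compound, compound 3, is `COc1ccc(Cl)cc1-n1ncc(-c2nnc(-c3ccc(Br)c(C)c3)o2)c1C`, not yet measured. It differs from compound 2 in one place: 4-bromo-3-methylphenyl in place of 4-chlorophenyl on an aromatic carbon. Part of this change is the reverse of the measured step, bromo back in place of chloro, which on the measured pair moved this assay by a modest amount. Within the data shown here, the added methyl group has no matching pair among the measured compounds, so its contribution cannot be read from the data. The expectation is nonetheless a rise, of about a number 0.84 log units higher from compound 2 to compound 3 (beyond the scatter), since the bromo-for-chloro part alone accounts for a modest step upward. Compound 3 is therefore expected to give roughly 5.35, within a range from 4.95 to 5.75.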

Compound 3, partition coefficient: 5.2
For compound 3 the middle estimate is 0.15 log units above the measured one, and the stated range covers the measured number.
By their numbers in this assay, from the lowest: compound 2; then compound 1; then compound 3.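

Compound 1 and compound 3 differ only by methyl in place of hydrogen on the phenyl group, so in this assay the methyl group now has a measured step of its own: a number 0.32 log units higher from compound 1 to compound 3 (beyond the scatter). The whole change of 4-chlorophenyl to 4-bromo-3-methylphenyl on the shared core gives a number 0.69 log units higher from compound 2 to compound 3 (beyond the scatter), which places compound 3 highest of the three and shows that chloro to bromo and hydrogen to methyl, each read from its own pair, can appear together in one compound with a higher number than either neighbour. Nothing measured here gives a reason for these shifts.

Every group shown at this place is a phenyl group carrying only a halogen, with or without a methyl, so the effect on the number of an amine or a carboxylic acid on that phenyl group remains open. Also open, as far as these compounds go, is whether methyl added to the 4-chlorophenyl group of compound 2 would give a step of similar size, as the methyl step rests on a single pair with bromo present.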